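The compounds below may be only part of what the source reports. "The series", "measured", "known", "first", "only" and "open" are said of these compounds alone.

Of the compounds shown here, three have so far been measured in an assay on HEK293 cells for agonist activity at transient receptor potential cation channel subfamily M member 8 (Homo sapiens), read by fluorescence and calcium flux, with a stated time of 15 min; on this read-out lower numbers stand for an effect already at smaller amounts and higher numbers for an effect only at larger amounts of compound. Compound 1 `Cc1ccc(OCC(=O)N(Cc2cccs2)c2ccccn2)cc1` gives 200 nM in this assay. Compound 2 `CCN(Cc1ccsc1)C(=O)COc1ccc(C)cc1` gives 88 nM in this assay, a lower number than compound 1, and the gap between the two lies beyond the usual scatter, so of the two reported numbers compound 1 stands as the higher one. Compound 3 `CCN1C(=O)C(Oc2ccc(C)cc2)C1c1cccs1` was reported in this assay only as "active" (no number reported), without a number, and offers no point of comparison. Compound 4 `Cc1ccc(OCC(=O)N(Cc2cccs2)c2ncccn2)cc1` has not yet been measured. For the measured compounds named here, it differs from compound 1 in one place: pyrimidin-2-yl in place of pyridin-2-yl on an amide-type nitrogen No measured pair shows what this change does here, so the expectation rests on compound 1 alone. A change of this kind is expected to shift the read-out only modestly, a 1.5-fold higher number from compound 1 to compound 4 (0.18 log units; within the scatter), towards a somewhat higher number, and the step may well fall within the scatter. For compound 4 the estimate in this assay is 300 nM, with a range from 100 nM to 900 nM.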

Compound 4, half-maximal effective concentration: 3700 nM
Beside the measured number, compound 4's estimate is 12-fold (1.09 log units) below it; the whole stated range lies below it.
By their numbers in this assay, from the lowest: compound 2; then compound 1; then compound 4.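

In this assay, pyrimidin-2-yl in place of pyridin-2-yl on the amide-type nitrogen gives a large step (a 19-fold higher number from compound 1 to compound 4 (1.27 log units; beyond the scatter)). For the compounds shown here, the earlier compounds offered no measured pair, and this one shows that the read-out at this position can respond strongly to a change that keeps the six-membered aromatic ring and its heavy-atom count, exchanging only one ring carbon for a nitrogen. Nothing available explains why the step is this large.

Two compounds cannot show whether the second ring nitrogen itself matters or only where it stands in the ring, which a pyrimidin-4-yl or pyrazin-2-yl group could help separate. As far as these compounds go, how a plain phenyl ring, with no ring nitrogen, would compare with compound 1 also remains open.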